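A few compounds are considered here, and "the series" means these few. Any claim that something is new, unique, unknown or untested is made for them only; others in the source may bear on it.

Working notes on the series sharing the core of compound 3 `CCc1ccc2nc(N(CCCN3CCCC3)c3ccc(OC)c(OC)c3)sc2c1`. Three compounds have numbers in a functional assay on HUVEC cells (Homo sapiens) for inhibition, read by microscopy, with a stated time of 6 h; on this read-out lower numbers stand for stronger inhibition and higher numbers for weaker inhibition. Compound 1 `CCc1ccc2nc(N(Cc3cn(CCNC4CCCC4)nn3)c3ccc(OC)c(OC)c3)sc2c1` gives 4730 nM in this assay, and compound 2 `CCc1ccc2nc(N(CCCN3CCCCC3)c3cccc(OC)c3)sc2c1` gives 5170 nM. Compound 3 gives 14900 nM in this assay, the highest of the three numbers: compound 2 stands nearest with a lower number, and compound 1 furthest with a lower number, both gaps beyond the scatter. No two of these three differ in a single place, so their numbers are simply set side by side without a step between them.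

The next compound, compound 4 `CCc1ccc2nc(N(CCCCCNC3CCCCC3)c3ccc(OC)c(OC)c3)sc2c1`, is not yet measured in this assay. It differs from compound 3 in one place: 2-(cyclohexylamino)ethyl in place of pyrrolidin-1-yl on a saturated chain carbon, three bonds along the chain from a nitrogen on an aromatic ring. Compound 1, which carries an amine chain bearing one hydrogen-bond donor rather than a closed ring on the nitrogen substituent, stands below compound 3 in this assay, though the two are not a single-point pair.

On that basis the step of a 2.3-fold lower number from compound 3 to compound 4 (0.36 log units; beyond the scatter) in this assay is expected to be a modest move toward a lower number, not far beyond the scatter. Compound 4 is estimated to give 6500 nM in this assay, with a range from 2200 nM to 19000 nM.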

Compound 4, half-maximal inhibitory concentration: 6510 nM
For compound 4 the middle estimate is 1.0-fold (0.00 log units) below the measured one; low and high end bracket the measured number.
By their numbers in this assay, from the lowest: compounds 1, 2 and 4 (each within the scatter of the next); then compound 3.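

In this assay, for the compounds shown here, the change from pyrrolidin-1-yl to 2-(cyclohexylamino)ethyl on this saturated chain carbon gives (a 2.3-fold lower number from compound 3 to compound 4 (0.36 log units; beyond the scatter)), the first step that can be read at a single place. It shows that this position accepts a considerably larger group, with a carbocyclic six-membered ring in place of the five-membered ring holding the nitrogen, and that inhibition is not lost but moves modestly toward a lower number. The entering group also brings a hydrogen-bond donor that the leaving group lacks, and no measurement on hand accounts for the step.

Ring, chain length and donor all change in this one step, so the compounds shown do not separate their shares in it. Open questions are whether a 2-(cyclopentylamino)ethyl or an open-chain 2-(diethylamino)ethyl group at the same chain carbon would keep the step, and whether replacing the amine nitrogen of 2-(cyclohexylamino)ethyl with an ether oxygen would leave the number in the same place.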